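The compounds below may be only part of what the source reports. "The series", "measured", "known", "first", "only" and "open" are said of these compounds alone.

Measured compounds:
compound 1 `CC1=CC[C@H](C(C)C)c2cc(C)c(OC(=O)c3ccc([N+](=O)[O-])cc3)cc21` gives 16.8% in a functional assay on U-251 cells (Homo sapiens) for antiproliferative activity, read by sulforhodamine B assay, with a stated time of 48 h, tested at 50 uM; on this read-out lower numbers stand for less inhibition and higher numbers for more inhibition at the one concentration tested (going by the name of the read-out)
compound 2 `CC1=CC[C@H](C(C)C)c2cc(C)c(OC(=O)c3cccc(Cl)c3)cc21` gives 0.9% in this assay

Going by the values given here, compound 2 stands lowest of the two numbers; the one step measured, a number 15.9 percentage points lower from compound 1 to compound 2 (beyond the scatter), is beyond the scatter. Compound 3 `CC1=CC[C@H](C(C)C)c2cc(C)c(OC(=O)c3cccc([N+](=O)[O-])c3)cc21` differs from compound 2 by nitro in place of chloro on an aromatic carbon. That step bears on the measured one only partly: a nitro group returns, but at another position of the ring, so compound 1 is no direct guide. A modest rise in this assay is expected, a number 9.1 percentage points higher from compound 2 to compound 3 (within the scatter), with compound 3 estimated at 10%, ranging from 0% to 25%.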

Compound 3, a percentage reported as inhibition, at one concentration (the size of the read-out at that concentration, not a potency): 44%
Beside the measured number, compound 3's estimate is 34 percentage points below it; the measured number lies above the stated range.
By their numbers in this assay, from the lowest: compound 2; then compound 1; then compound 3.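

In this assay, this aromatic carbon, meta to a large group, does not treat chloro and nitro alike: the change brings a large step of a number 43.1 percentage points higher from compound 2 to compound 3 (beyond the scatter) and goes beyond the scatter. The place of the nitro group also counts, since 3-nitrophenyl in place of 4-nitrophenyl gives a step of a number 27.2 percentage points higher from compound 1 to compound 3 (beyond the scatter) that separates position from group, which the earlier pair could not do. Nothing at hand accounts for either step.

From the compounds shown here alone, how an amine or a methoxy group would read at this same carbon stays open. So does whether a carboxylic acid would follow nitro or chloro there.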